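This account rests on a few compounds, and the source may have more. Where it says the series, first, only, none or still open, it means among the compounds named here.

Compound 1 `Fc1ccc(COc2cccc(-c3cn(C4CN5CCC4CC5)nn3)c2)cc1` is measured in an assay on HEK293 cells for displacement of a labelled ligand from Neuronal acetylcholine receptor; alpha4/beta2 (Homo sapiens), read by scintillation counting, with a stated time of 120 min (on this read-out lower numbers stand for stronger inhibition and higher numbers for weaker inhibition), and gives 1010 nM, the highest of the three numbers shown. Its nearest neighbour is compound 2 `Fc1ccc(COc2cccc(-c3cn([C@@H]4CN5CCC4CC5)nn3)c2)cc1`, which differs only in that a stereocentre at a saturated ring carbon is drawn with a configuration, and which gives 537 nM; the step of a 1.9-fold lower number from compound 1 to compound 2 (0.27 log units; within the scatter) stays within the scatter, as the comparison the fact that one of compounds 1 and 2 is drawn with a defined configuration and the other without, at the place where they differ also shows. Compound 3 `Oc1ccc(-c2cn([C@@H]3CN4CCC3CC4)nn2)cc1` gives 461 nM, and its number lies furthest from that of compound 1, beyond the scatter.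

Compound 4 `FCCCOc1cccc(-c2cn(C3CN4CCC3CC4)nn2)c1` has not yet been measured in this assay. It arises from compound 1 by the change (2-fluoroethyl in place of 4-fluorophenyl on a saturated chain carbon bound to an oxygen on an aromatic ring), that is, 2-fluoroethyl in place of 4-fluorophenyl on a saturated chain carbon bound to an oxygen on an aromatic ring. Among the compounds with values here, none of the measured steps touches this part of the molecule: the only step on record, from compound 1 to compound 2, concerns a stereocentre, and compound 3 differs in several places at once. The account therefore has no measured guide for the size or direction of the step, and a wide range must be allowed. Compound 4 is expected to give 1500 nM, with a range from 300 nM to 7500 nM, which means the step of a 1.5-fold higher number from compound 1 to compound 4 (0.17 log units; within the scatter) is the estimate.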

Compound 4, inhibition constant: 3890 nM
Beside the measured number, compound 4's estimate is 2.6-fold (0.41 log units) below it; low and high end bracket the measured number.
By their numbers in this assay, from the lowest: compounds 3, 2 and 1 (each within the scatter of the next, the first and the last beyond it); then compound 4.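

Within the data shown here, the exchange of 4-fluorobenzyl for 3-fluoropropyl, on a saturated chain carbon bound to an oxygen on an aromatic ring, gives the first measured step at this place in this assay: a 3.9-fold higher number from compound 1 to compound 4 (0.59 log units; beyond the scatter). This shows that the place is not indifferent to what it carries, and that an open fluorinated chain, with its aromatic ring gone and fewer heavy atoms, gives weaker inhibition than the 4-fluorobenzyl group of compound 1, something the earlier compounds could not show because none of their listed steps touched this group: the fact that one of compounds 1 and 2 is drawn with a defined configuration and the other without, at the place where they differ Nothing measured so far speaks to why this exchange moves the number, as the one comparison on record concerns a different feature of the molecule.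

As far as these compounds go, whether the difference follows the aromatic ring, the length of the chain or the fluorine stays open, and a plain propyl, an unsubstituted benzyl or a cyclohexylmethyl at this place would be needed to separate these. From the compounds shown here alone, it is also open whether the step would keep its size in a compound carrying the configuration drawn in compound 2.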